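The source may hold more compounds than are shown below. What is called first, only, known or untested is meant among the compounds shown, and "the series" means these compounds.

Of the compounds shown here, three built on one shared core have been tested in a functional assay on A549 cells (Homo sapiens) for antiproliferative activity, read by MTT assay, with a stated time of 72 h; a lower number here means a stronger inhibitor, a higher number a weaker inhibitor. Compound 1 `CCCSc1nc(Cl)c2c(n1)N(Cc1ccccc1)C(C(=O)O)N2` gives 10700 nM, compound 2 `CCCSc1nc(Cl)c2c(n1)N(Cc1cccs1)C(C(=O)N1CCN(C)CC1)N2` gives 6420 nM, and compound 3 `CCCSc1nc(Cl)c2c(n1)N(Cc1ccccc1)C(C(=O)NCCC1=CCc3ccccc31)N2` gives 48800 nM. Compound 2 holds the lowest of the three numbers: its gap to compound 1 lies within the scatter, while its gap to compound 3 lies beyond it. Compound 4 `CCCSc1nc(Cl)c2c(n1)N(Cc1ccccc1)C(C(=O)N1CCN(C)CC1)N2` has not yet been measured in this assay. It differs from compound 2 in a single place: phenyl in place of thiophen-2-yl on a saturated chain carbon bound to a nitrogen on an aromatic ring in a ring. Within the data shown here, no pair of measured compounds isolates this change, so no shift beyond the scatter is expected in either direction. In this assay the step is expected to be a 1.1-fold higher number from compound 2 to compound 4 (0.04 log units; within the scatter). Compound 4 is therefore estimated at 7000 nM, within a range from 3000 nM to 16000 nM.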

Compound 4, half-maximal inhibitory concentration: 2800 nM
Beside the measured number, compound 4's estimate is 2.5-fold (0.40 log units) above it; the whole stated range lies above it.
By their numbers in this assay, from the lowest: compound 4; then compounds 2 and 1 (each within the scatter of the next); then compound 3.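

In this assay, a step of a 2.3-fold lower number from compound 2 to compound 4 (0.36 log units; beyond the scatter) for phenyl in place of thiophen-2-yl shows that this saturated chain carbon bound to a nitrogen on an aromatic ring does respond to the group it carries. Among these compounds, a second step of a 3.8-fold lower number from compound 1 to compound 4 (0.58 log units; beyond the scatter) gives the first reading at the carbonyl carbon, with 4-methylpiperazin-1-yl in place of hydroxy. Going by these compounds, each step rests on a single pair of compounds, so how pyridin-2-yl in place of phenyl, or morpholin-4-yl in place of 4-methylpiperazin-1-yl, would read remains open. Nothing shown accounts for either step.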